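Removing one chloro from compound 1

The compounds below may be only part of what the source reports. "The series", "measured", "known", "first", "only" and "open" are said of these compounds alone.

- compound 1 `COc1cc(-c2ncnn2-c2ccc(Cl)cc2Cl)cc(OC)c1OC`: > 10000 nM
- compound 2 `COc1ccc(-c2ncnn2-c2cc(OC)c(OC)c(OC)c2)cc1`: 120 nM
- compound 3 `CCOc1ccc(-c2ncnn2-c2cc(OC)c(OC)c(OC)c2)cc1Cl`: 3 nM

In a functional assay on HL-60 cells (Homo sapiens) for antiproliferative activity, read by MTT assay, with a stated time of 72 h (on this read-out higher numbers stand for weaker inhibition and lower numbers for stronger inhibition), compound 1 stands at > 10000 nM, which is a limit and not a number. Compound 2 (120 nM) and compound 3 (3 nM) show that strong inhibition occurs among these compounds, though no single change links either one to compound 1. Compound 4 `COc1cc(-c2ncnn2-c2ccc(Cl)cc2)cc(OC)c1OC` differs from compound 1 in one place: hydrogen in place of chloro on an aromatic carbon turns 2,4-dichlorophenyl into 4-chlorophenyl, with hydrogen in place of chloro on an aromatic carbon. A step toward stronger inhibition in this assay is expected, though its size is uncertain and the result could again be only a limit. The estimated change is an at least 3.3-fold lower number from compound 1 to compound 4 (0.52 log units; beyond the scatter). Compound 4 is expected at 3000 nM, within an estimated range of 400 nM to 10000 nM.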

Compound 4, half-maximal inhibitory concentration: > 10000 nM
Compound 4 gave a limit, no number; the forecaster's own chance of this, stated with the estimate: 45%; middle value at least 3.3-fold (0.52 log units) away from the limit.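

Compound 1 and compound 4 both end at the same limit rather than a number, so no step between them can be read: the limit of > 10000 nM in this assay, at which 2 of the 4 values shown sit.

Still open, from the compounds shown here alone, is how far past that limit each compound lies, and whether removing this chloro changes inhibition at all.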